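The compounds below may be only part of what the source reports. "The series", "measured", "known", "first", "only" and "open" are said of these compounds alone.

Measured in a functional assay on the whole organism (artery, strain albino) with Rattus norvegicus as the target, with a stated time of 240 min, at a dose of 10 mg/kg by the oral route; a lower number here means less inhibition, a higher number more inhibition at the dose given (going by the name of the read-out):
compound 1 `CC1=C(C(=O)Nc2ccc([N+](=O)[O-])cc2)C(c2ccc(Br)cc2)N=C(SCc2ccccc2)N1`: compound 1 gives 27.7%
compound 2 `CC1=C(C(=O)Nc2ccc([N+](=O)[O-])cc2)C(c2ccc(Br)cc2)N=C(SCc2ccccc2Cl)N1`: compound 2 gives 15.4%
compound 3 `CC1=C(C(=O)Nc2ccc([N+](=O)[O-])cc2)C(c2ccc(Br)cc2)N=C(SCc2cccc(Cl)c2)N1`: compound 3 gives 11.8%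

Compound 3 holds the lowest of the three numbers; its gap to compound 2 lies within the scatter, while a number 15.9 percentage points lower from compound 1 to compound 3 (beyond the scatter) lies beyond it. Compound 4 `CC1=C(C(=O)Nc2ccc([N+](=O)[O-])cc2)C(c2ccc(Br)cc2)N=C(SCc2ccc(Cl)cc2)N1` differs from compound 3 by 4-chlorophenyl in place of 3-chlorophenyl on a saturated chain carbon bound to a sulfur. The step that bears most directly on this is a number 3.6 percentage points lower from compound 2 to compound 3 (within the scatter), which moved the chloro on the benzyl group without leaving the scatter; the steps of a number 12.3 percentage points lower from compound 1 to compound 2 (beyond the scatter) and a number 15.9 percentage points lower from compound 1 to compound 3 (beyond the scatter) concern adding the chloro rather than moving it and were modest. Moving the same chloro once more is therefore expected to give no step beyond the scatter, in either direction. For compound 4 the estimate is 14%, range 4% to 26%, an expected step of a number 2.2 percentage points higher from compound 3 to compound 4 (within the scatter).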

Compound 4, a percentage reported as inhibition, in the whole organism at one dose (the size of the read-out at that dose, not a potency): 29.7%
Beside the measured number, compound 4's estimate is 15.7 percentage points below it; the whole stated range lies below it.
By their numbers in this assay, from the lowest: compounds 3 and 2 (each within the scatter of the next); then compounds 1 and 4 (each within the scatter of the next).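

In this assay the place of the chloro on the benzyl group does matter: a number 17.9 percentage points higher from compound 3 to compound 4 (beyond the scatter) and a number 14.3 percentage points higher from compound 2 to compound 4 (beyond the scatter) whereas the earlier step from 2-chlorophenyl to 3-chlorophenyl stayed within the scatter. With a number 2 percentage points higher from compound 1 to compound 4 (within the scatter) the 4-chlorophenyl group stays within the scatter of the plain benzyl group, so the drop on adding chloro holds for compounds 2 and 3 only, and compound 4 goes against it. No measurement here accounts for this dependence on position.

Open, as far as these compounds go, is whether a methoxy or an amino group in place of the chloro follows the same order. Also open, from the compounds shown here alone, is whether a longer chain in place of the saturated chain carbon bound to a sulfur keeps it.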